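This account rests on a few compounds, and the source may have more. Where it says the series, first, only, none or still open, it means among the compounds named here.

Measured compounds, with the read-out in a functional assay on MCF7 cells (Homo sapiens) for inhibition; on this read-out higher numbers stand for weaker inhibition and lower numbers for stronger inhibition:

- compound 1 `CC(C)(C)NC(=O)N1CC1C#N`: 190000 nM
- compound 2 `CCOC(=O)c1ccc(NC(=O)N2CC2C#N)cc1`: 2100 nM
- compound 3 `N#CC1CN1C(=O)Nc1ccc(Cl)cc1Cl`: 1100 nM

Three compounds share the core of compound 1 and differ only in the group on the urea nitrogen. In this assay compound 1, with its tert-butyl group, gives 190000 nM, the highest of the three numbers. Compound 2 stands second highest; its nearest neighbour is compound 3, whose number is lower by an amount that lies within the usual scatter, so the two cannot be ordered. Compound 1 is furthest from compound 2, with a gap well beyond the scatter.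

Compound 4 `N#CC1CN1C(=O)Nc1ccc(C(F)(F)F)cc1` has not been measured in this assay. It differs from compound 2 in one place: trifluoromethyl in place of ethoxycarbonyl on an aromatic carbon. Within the data shown here, both aryl ureas measured so far, compound 2 and compound 3, sit in the same low-micromolar band, and no measured pair isolates the effect of this particular exchange. The expectation is therefore a step from compound 2 to compound 4 of a 1.3-fold lower number from compound 2 to compound 4 (0.12 log units; within the scatter), which is not beyond the scatter in either direction. On that basis compound 4 is estimated at 1600 nM in this assay, within a range of 400 nM to 6000 nM.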

Compound 4, half-maximal inhibitory concentration: 1400 nM
Compound 4: the middle estimate sits 1.1-fold (0.06 log units) above what was measured; the measured number falls inside the stated range.
By their numbers in this assay, from the lowest: compounds 3, 4 and 2 (each within the scatter of the next); then compound 1.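

In this assay, among these compounds, the exchange of ethoxycarbonyl for trifluoromethyl, on an aromatic carbon para to a group of 8 heavy atoms, gives a 1.5-fold lower number from compound 2 to compound 4 (0.18 log units; within the scatter) and so provides the first reading of a single-place change, with no difference that can be claimed. At this place, then, a group of 5 heavy atoms with 2 hydrogen-bond acceptors and a double bond outside the aromatic ring can give way to one of 4 heavy atoms with no hydrogen-bond acceptors, and the read-out stays within the scatter. No accompanying measurement offers an explanation for this result.

This single exchange does not settle whether any group at this place can move the number beyond the scatter, and a carboxylic acid, an amine or a longer ester chain such as butoxycarbonyl would test that. Also open, going by these compounds, is whether plain hydrogen at this place would stay within the scatter of compound 2 and compound 4, which would show whether the group there matters at all.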